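A Methylphenyl Replaces a Methylfuranyl on the Shared Core

The source may report more compounds than this note shows. Statements on the series, on what has been measured and on what is new or still open speak of the compounds shown alone.

Of the compounds shown here, two built on a shared core have been tested in a functional assay on HCT-15 cells (Homo sapiens) for cytotoxicity, read by ELISA, with a stated time of 4 days; a lower number here means a stronger inhibitor, a higher number a weaker inhibitor. Compound 1 `Cc1ccsc1-c1cc(-c2ccoc2)cc(-c2ccco2)n1` gives 640 nM in this assay. Compound 2 `Cc1ccc(-c2cc(-c3ccoc3)cc(-c3ccc(Cl)s3)n2)o1` gives 790 nM in this assay, the higher of the two numbers, but its distance from compound 1 lies within the scatter, so the two compounds cannot be told apart on these data.

Compound 3 `Cc1ccc(-c2cc(-c3ccoc3)cc(-c3ccc(Cl)s3)n2)cc1` has not yet been measured. It differs from compound 2 in one place: 4-methylphenyl in place of 5-methylfuran-2-yl on an aromatic carbon. Going by the values given here, no pair of measured compounds differs in only one place, so no measured step is available to guide the expectation for this change. Among the compounds with values here, the only comparison on hand, between compound 1 and compound 2, shows that varying the groups around the shared core left the number almost where it was.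

On that basis the account expects a step of a 1.0-fold higher number from compound 2 to compound 3 (0.01 log units; within the scatter) that stays within the scatter, with no settled direction. Compound 3 is estimated at 800 nM in this assay, within a range from 300 nM to 2500 nM.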

Compound 3, half-maximal inhibitory concentration: 1170 nM
Beside the measured number, compound 3's estimate is 1.5-fold (0.17 log units) below it; the measured number falls inside the stated range.
By their numbers in this assay, from the lowest: compounds 1, 2 and 3 (each within the scatter of the next).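

In this assay, going by these compounds alone, the exchange of 5-methylfuran-2-yl for 4-methylphenyl provides the first step between measured compounds that differ in one place, a 1.5-fold higher number from compound 2 to compound 3 (0.17 log units; within the scatter), and that step lies within the scatter. At this aromatic carbon next to the ring nitrogen, a five-membered aromatic ring with 1 hetero atom and a six-membered aromatic ring of carbon only therefore cannot be told apart on these data, even though the entering group has no hydrogen-bond acceptor and the leaving group has 1. Nothing on hand offers an explanation for how the number responds to this exchange.

The compounds shown carry only aromatic rings at this place, so it remains open whether an amine, a carboxylic acid or a longer chain there would leave the number within the scatter as well. Going by these compounds, the 5-chlorothiophen-2-yl and furan-3-yl groups also remain without a single-place comparison, so the contribution of either one to the number, for instance on replacement by a simple phenyl ring, is still unknown.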